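Shifting a chloro around the phenoxy ring

A few compounds are considered here, and "the series" means these few. Any claim that something is new, unique, unknown or untested is made for them only; others in the source may bear on it.

Three compounds have been measured in an assay on isolated protein for inhibition of Fatty-acid amide hydrolase 1 (Homo sapiens), read by fluorescence; on this read-out lower numbers stand for stronger inhibition and higher numbers for weaker inhibition:
compound 1 `O=C(Oc1ccc([N+](=O)[O-])cc1)N1CCN(S(=O)(=O)c2ccc(Oc3ccccc3)cc2)CC1` gives 322 nM
compound 2 `O=C(Oc1ccc([N+](=O)[O-])cc1)N1CCN(S(=O)(=O)c2ccc(Oc3ccc(Cl)c(Cl)c3)cc2)CC1` gives 317 nM
compound 3 `O=C(Oc1ccc([N+](=O)[O-])cc1)N1CCN(S(=O)(=O)c2ccc(Oc3cccc(Cl)c3)cc2)CC1` gives 380 nM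

Compound 3 has the largest of the three numbers, yet a 1.2-fold higher number from compound 1 to compound 3 (0.07 log units; within the scatter) and a 1.2-fold higher number from compound 2 to compound 3 (0.08 log units; within the scatter) both lie within the scatter, so the three compounds cannot be told apart. Compound 4 `O=C(Oc1ccc([N+](=O)[O-])cc1)N1CCN(S(=O)(=O)c2ccc(Oc3ccc(Cl)cc3)cc2)CC1` is the next step: 4-chlorophenyl in place of 3-chlorophenyl on an oxygen on an aromatic ring. Going by the values given here, the steps that bear on it, a 1.2-fold higher number from compound 1 to compound 3 (0.07 log units; within the scatter) and a 1.0-fold lower number from compound 1 to compound 2 (0.01 log units; within the scatter), show that adding chloro to this ring changed nothing beyond the scatter, so no step beyond the scatter is expected in this assay for compound 4, a shift of a 1.1-fold lower number from compound 3 to compound 4 (0.05 log units; within the scatter). Compound 4 is estimated at 340 nM, with a range from 180 nM to 650 nM.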

Compound 4, half-maximal inhibitory concentration: 153 nM
Compound 4: middle estimate off by 2.2-fold (0.35 log units), on the high side; the whole stated range lies above it.
By their numbers in this assay, from the lowest: compound 4; then compounds 2, 1 and 3 (each within the scatter of the next).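

Moving the chloro matters in this assay: 4-chlorophenyl in place of 3-chlorophenyl gives a 2.5-fold lower number from compound 3 to compound 4 (0.40 log units; beyond the scatter), the first step in this set beyond the scatter. The other two comparisons also go beyond it, a 2.1-fold lower number from compound 1 to compound 4 (0.32 log units; beyond the scatter) and a 2.1-fold lower number from compound 2 to compound 4 (0.32 log units; beyond the scatter), so the lower number belongs to 4-chlorophenyl alone, and compound 2, with 3,4-dichlorophenyl, does not share it. Even so, the same chloro change cannot be shown to differ between the two cores that carry it: the same change on two cores in this assay, a 1.2-fold higher number (0.07 log units; within the scatter) from compound 1 to compound 3 and a 2.1-fold higher number (0.32 log units; beyond the scatter) from compound 4 to compound 2, 1.8-fold (0.24 log units) apart, within the scatter of two such steps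

As far as these compounds go, whether 2-chlorophenyl, 4-methoxyphenyl or 4-aminophenyl would give a lower or a higher number than compound 4 remains open.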